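Heteroaryl in Place of Phenyl on a Saturated Ring Carbon

The compounds below may be only part of what the source reports. "The series", "measured", "known", "first", "only" and "open" are said of these compounds alone.

compound 1 `Cc1cccc(NC(=O)CN2CCC(c3nccs3)CC2)c1` — 1 nM
compound 2 `Cc1cccc(NC(=O)CN2CCC(c3ccccc3)CC2)c1` — 170 nM

In a functional assay on HEK293 cells for agonist activity at D(4) dopamine receptor (Homo sapiens), read by FLIPR (a lower number here means that less compound is needed, a higher number that more compound is needed for the effect), compound 2 gives 170 nM, the higher of the two numbers measured. Compound 1 gives 1 nM. Among the measured compounds shown here, the one measured step that bears on the new compound is a 170-fold higher number from compound 1 to compound 2 (2.23 log units; beyond the scatter), a large change for a single group. Compound 3 `Cc1cccc(NC(=O)CN2CCC(c3ccc(O)cn3)CC2)c1` differs from compound 2 by 5-hydroxypyridin-2-yl in place of phenyl on a saturated ring carbon. Since a six-membered aromatic ring with a hetero atom again replaces phenyl here, a large downward step is expected, a 17-fold lower number from compound 2 to compound 3 (1.23 log units; beyond the scatter), though smaller than a 170-fold higher number from compound 1 to compound 2 (2.23 log units; beyond the scatter) would suggest. Compound 3 is estimated at 10 nM, within 2 nM to 60 nM.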

Compound 3, half-maximal effective concentration: 3.8 nM
Beside the measured number, compound 3's estimate is 2.6-fold (0.42 log units) above it, within the range that was stated.
By their numbers in this assay, from the lowest: compound 1; then compound 3; then compound 2.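

In this assay the large drop in the number at this saturated ring carbon is not confined to 1,3-thiazol-2-yl: 5-hydroxypyridin-2-yl, a six-membered aromatic ring, also gives a large step (a 45-fold lower number from compound 2 to compound 3 (1.65 log units; beyond the scatter)). The two heteroaryl groups are not equivalent, though, as a modest difference beyond the scatter remains (a 3.8-fold higher number from compound 1 to compound 3 (0.58 log units; beyond the scatter)). Nothing measured here accounts for either step. As far as these compounds go, the ring nitrogen and the hydroxyl enter together, so their separate shares stay open; a plain pyridin-2-yl or a methoxy in place of the hydroxyl would separate them.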